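Pyrazoline series: trimethoxyphenyl in place of fluorophenyl

This account rests on a few compounds, and the source may have more. Where it says the series, first, only, none or still open, it means among the compounds named here.

Compound 1 `Fc1ccc(C2CC(c3ccccc3)=NN2c2ccc(-c3ccccc3)nn2)cc1` gives 10000 nM in a functional assay on Caco-2 cells (Homo sapiens) for antiproliferative activity, read by MTT assay, with a stated time of 24 h; a lower number here means a stronger inhibitor, a higher number a weaker inhibitor. Compound 3 `COc1ccc(C2=NN(c3ccc(-c4ccccc4)nn3)C(c3ccc(F)cc3)C2)cc1` gives 18100 nM in this assay. For compound 2 `COc1ccc(C2=NN(c3ccc(-c4ccccc4)nn3)C(c3ccc(Cl)cc3)C2)cc1` the this assay reports only a limit, > 100000 nM, which is the limit of > 100000 nM in this assay, at which 1 of the 3 values shown sits. Among the two numbers known, compound 3 sits highest, with compound 1 nearest; the step of a 1.8-fold higher number from compound 1 to compound 3 (0.26 log units; within the scatter) stays within the scatter, so these two cannot be ordered. The step of an at least 5.5-fold lower number from compound 2 to compound 3 (0.74 log units; beyond the scatter) is the only one beyond the scatter and it starts from a limit.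

Compound 4 `COc1ccc(C2=NN(c3ccc(-c4ccccc4)nn3)C(c3cc(OC)c(OC)c(OC)c3)C2)cc1` is not yet measured. It differs from compound 3 by 3,4,5-trimethoxyphenyl in place of 4-fluorophenyl on a saturated ring carbon. Neither measured step covers this exchange directly: the step of a 1.8-fold higher number from compound 1 to compound 3 (0.26 log units; within the scatter) shows that an added methoxy group on another ring changed little, and the step of an at least 5.5-fold lower number from compound 2 to compound 3 (0.74 log units; beyond the scatter) concerns only which halogen sits on the ring that is now replaced. The step expected a 1.2-fold lower number from compound 3 to compound 4 (0.08 log units; within the scatter) is therefore one not beyond the scatter. Compound 4 is estimated at 15000 nM, with a range from 4000 nM to 60000 nM.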

Compound 4, half-maximal inhibitory concentration: > 100000 nM
Compound 4: only a limit was reported; the forecaster's own chance of this, stated with the estimate: 15%; middle value at least 6.6-fold (0.82 log units) from the limit.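

In this assay the exchange of 4-fluorophenyl for 3,4,5-trimethoxyphenyl on the saturated ring carbon next to the ring nitrogen gives an at least 5.5-fold higher number from compound 3 to compound 4 (0.74 log units; beyond the scatter) and shows that this position does not accept every substituted phenyl group with a number retained. Among the compounds shown, only compound 1 and compound 3, both with 4-fluorophenyl here, give a number rather than a limit, and the step between compound 2 and compound 4 cannot be read. The value of compound 4 is a limit, the same one that compound 2 carries: the limit of > 100000 nM in this assay, at which 2 of the 4 values shown sit.

Open, as far as these compounds go, is whether a single methoxy group on this phenyl ring, or an amine or a carboxylic acid in its place, stays clear of the limit. Open too, from the compounds shown here alone, is whether the number of methoxy groups or the removal of fluorine matters more, as this exchange changes both at once.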